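A few compounds are considered here, and "the series" means these few. Any claim that something is new, unique, unknown or untested is made for them only; others in the source may bear on it.

Measured so far in a functional assay on T47D cells (Homo sapiens) for antiproliferative activity, read by MTT assay, with a stated time of 72 h; a higher number here means a weaker inhibitor, a lower number a stronger inhibitor:
- Compound 1 `COc1ccc(C(=O)Nc2cc(OC)c(OC)c(OC)c2)cc1[N+](=O)[O-]` gives 6000 nM.
- Compound 2 `COc1ccc(C(=O)Nc2cc(OC)c(OC)c(OC)c2)cc1N` gives > 100000 nM.
- Compound 3 `COc1ccc(C(=O)Oc2cc(OC)c(OC)c(OC)c2)cc1[N+](=O)[O-]` gives 29600 nM.

The value of compound 2 is not a number but a limit of this assay, (the limit of > 100000 nM in this assay, at which 1 of the 3 values shown sits). Compound 1 and compound 2 differ in one place only: amino in place of nitro on an aromatic carbon. That change brought an at least 16-fold higher number from compound 1 to compound 2 (1.22 log units; beyond the scatter), so the measurable inhibition of compound 1 was lost.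

Compound 3 has the highest of the two numbers in this assay; how its core differs from the core of compound 1 is not broken down here. Compound 4 `COc1ccc(C(=O)Oc2cc(OC)c(OC)c(OC)c2)cc1N` has not been measured yet. It differs from compound 3 by amino in place of nitro on an aromatic carbon, the same change, at the same place, that was made from compound 1 to compound 2.

Since the earlier step was an at least 16-fold higher number from compound 1 to compound 2 (1.22 log units; beyond the scatter), a step of similar size is expected here, a 10-fold higher number from compound 3 to compound 4 (1.01 log units; beyond the scatter), and compound 3 already starts from a weaker position than compound 1. Compound 4 is therefore expected to give about 300000 nM in this assay, most likely reported only as a limit, somewhere between 100000 nM and 1000000 nM.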

Compound 4, half-maximal inhibitory concentration: > 100000 nM
Compound 4: only a limit was reported (the forecaster's own chance of this, stated with the estimate: 80%); the middle value is on the limit's open side.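

In this assay, amino in place of nitro on the core of compound 3 brought an at least 3.3-fold higher number from compound 3 to compound 4 (0.52 log units; beyond the scatter), so the loss of measurable inhibition seen on the core of compound 1 appeared on this second core too: the same change on two cores in this assay, an at least 16-fold higher number (1.22 log units; beyond the scatter) from compound 1 to compound 2 and an at least 3.3-fold higher number (0.52 log units; beyond the scatter) from compound 3 to compound 4; the limit leaves it open whether they differ

Among these compounds, this agreement rests on only two pairs of compounds, and neither pair goes against it, but it shows only the direction of the change and says nothing about any other group or place. How large the loss really is on each core, and whether it is equally large on both, stays unknown, because compound 2 and compound 4 each gave only a limit rather than a number: the limit of > 100000 nM in this assay, at which 2 of the 4 values shown sit.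

The compounds shown leave open whether another group in this place, such as a methyl, a hydroxyl or an acetamide, would retain inhibition. On these data alone, it is also open how a plain hydrogen or a carboxylic acid there would compare with the nitro group of compound 1 and compound 3 in this assay.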